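The source may report more compounds than this note shows. Statements on the series, on what has been measured and on what is new or still open speak of the compounds shown alone.

Among the compounds with values here, compound 1 `O=C(/C=C/c1ccc(O)c(O)c1)OCc1c(-c2ccccc2)no[n+]1[O-]` is the only compound of this set that gives a number in a functional assay on LOX IMVI cells (Homo sapiens) for cytotoxicity, read by resazurin assay, with a stated time of 72 h; a higher number here means a weaker inhibitor, a lower number a stronger inhibitor: compound 1 gives 13300 nM. Within the data shown here, the other measured compound, compound 2 `COc1cc(/C=C/C(=O)OCc2ccc(OCc3c(-c4ccccc4)no[n+]3[O-])cc2)ccc1O`, differs from compound 1 in more than one place, and the two values show only that compound 2 falls short of a number. In this assay compound 2 reaches only the limit of the test, > 50000 nM, and this is the limit of > 50000 nM in this assay, at which 1 of the 2 values shown sits.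

Compound 3 `COc1cc(/C=C/C(=O)OCc2c(-c3ccccc3)no[n+]2[O-])ccc1O` keeps the core of compound 1 and differs from it in a single place: methyl in place of hydrogen on an oxygen on an aromatic ring. Read one bond further out, the change is hydroxy to methoxy, or 3,4-dihydroxyphenyl to 4-hydroxy-3-methoxyphenyl. Among the measured compounds shown here, no measured pair here isolates this change, and the expectation rests on compound 1 alone. The step from compound 1 to compound 3 is expected to be a 1.9-fold higher number from compound 1 to compound 3 (0.27 log units; within the scatter), a modest weakening that may just pass beyond the usual scatter. Compound 3 is therefore estimated to give 25000 nM in this assay, within a range from 8000 nM to 50000 nM.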

Compound 3, half-maximal inhibitory concentration: 13800 nM
The estimate for compound 3 lay 1.8-fold (0.26 log units) above the measured number, within the range that was stated.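

In this assay, putting methyl in place of hydrogen on an oxygen on an aromatic ring gives a 1.0-fold higher number from compound 1 to compound 3 (0.02 log units; within the scatter), so turning hydroxy into methoxy at this position leaves the two compounds indistinguishable. On this core, then, the hydrogen of that hydroxy group is not needed for the cytotoxicity seen in these cells, something compound 1 alone could not show. The measurements shown give no reason why the change has so little effect on the number.

Going by these compounds, whether this tolerance extends beyond a single methyl remains open, since an ethyl group or a longer chain on the same oxygen might give a different result. The compounds shown also leave open what would happen if the hydroxy group that remains in compound 3 were replaced, for example by an amine or a carboxylic acid.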